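The compounds below may be only part of what the source reports. "The series", "measured", "known", "first", "only" and "open" are said of these compounds alone.

Measured so far:
compound 1 `CCOC(=O)c1cc2ccc(Oc3ccccc3)cc2s1`: > 100000 nM (a limit of the assay)
compound 2 `CCOC(=O)c1cc2ccc(Oc3ccncc3)cc2s1`: 42400 nM

For the measured compounds named here, in an ADME assay on H1-HeLa cells (Homo sapiens) for cytotoxicity, read by MTT assay, with a stated time of 3 days (on this read-out lower numbers stand for higher toxicity in this test and higher numbers for lower toxicity in this test), compound 2 gives 42400 nM, the only actual number so far. Compound 3 `CCOC(=O)c1cc2ccc(OC)cc2s1` carries methyl in place of pyridin-4-yl on an oxygen on an aromatic ring. Going by the values given here, one measured step bears on this: an at least 2.3-fold lower number from compound 1 to compound 2 (0.37 log units; beyond the scatter), with pyridin-4-yl in place of phenyl at that same place. Removing pyridin-4-yl is therefore expected to give a modest rise in this assay, just beyond the scatter. The expected step is a 2.1-fold higher number from compound 2 to compound 3 (0.33 log units; beyond the scatter). For compound 3 the estimate is 90000 nM, with an expected range from 35000 nM to 200000 nM.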

Compound 3, half-maximal cytotoxic concentration: 70900 nM
Compound 3: middle estimate off by 1.3-fold (0.10 log units), on the high side, and the stated range covers the measured number.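

In this assay, methyl in place of pyridin-4-yl gives a 1.7-fold higher number from compound 2 to compound 3 (0.22 log units; within the scatter), so on this oxygen the pyridin-4-yl ring can be replaced by methyl with no shift beyond the scatter. Methyl in place of phenyl gives an at least 1.4-fold lower number from compound 1 to compound 3 (0.14 log units; that floor lies within the scatter), a floor that does not separate the two groups. The value of compound 1 is a limit of the assay and not a number: the limit of > 100000 nM in this assay, at which 1 of the 3 values shown sits.

Still open, from the compounds shown here alone, is whether a longer chain, an amine or a carboxylic acid carried on this oxygen would move the number beyond the scatter.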